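Series notes: cyclohexyl for ethyl on the shared core

A few compounds are considered here, and "the series" means these few. Any claim that something is new, unique, unknown or untested is made for them only; others in the source may bear on it.

Going by the values given here, compound 2 `CC[C@H]1CC(Cl)=C([Si](C)(C)C)[C@@H](C2CCCCC2)O1` gives 29000 nM in a functional assay on WiDr cells (Homo sapiens) for antiproliferative activity (a lower number here means a stronger inhibitor of growth, a higher number a weaker inhibitor of growth), the highest of the two numbers measured so far. Its nearest neighbour is compound 1 `C[C@H]1CC(Cl)=C([Si](C)(C)C)[C@@H](C2CCCCC2)O1`, which gives 15000 nM; the step of a 1.9-fold higher number from compound 1 to compound 2 (0.29 log units; within the scatter) lies within the scatter. Compound 3 `C[Si](C)(C)C1=C(Cl)C[C@H](C2CCCCC2)O[C@@H]1C1CCCCC1` is not yet measured. The change from compound 2 is cyclohexyl in place of ethyl on a saturated ring carbon. Among the compounds with values here, the only measured step that bears on the same position, a 1.9-fold higher number from compound 1 to compound 2 (0.29 log units; within the scatter), involved a far smaller group and did not move the number beyond the scatter, so it gives little guidance on a change of this size; no measured compound carries a group of this kind at that position. The step from compound 2 to compound 3 in this assay is therefore expected to be a 1.5-fold lower number from compound 2 to compound 3 (0.16 log units; within the scatter), with a wide range. Compound 3 is estimated at 20000 nM, between 4000 nM and 90000 nM.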

Compound 3, concentration for 50% growth inhibition: 30000 nM
Estimate against measurement, compound 3: 1.5-fold (0.18 log units) below; the range from low to high includes it.
By their numbers in this assay, from the lowest: compounds 1, 2 and 3 (each within the scatter of the next).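

In this assay, cyclohexyl in place of ethyl on the saturated ring carbon next to the ring oxygen gives a 1.0-fold higher number from compound 2 to compound 3 (0.01 log units; within the scatter), and cyclohexyl in place of methyl there gives a 2.0-fold higher number from compound 1 to compound 3 (0.30 log units; within the scatter). The methyl-to-ethyl step covered only a small change, whereas these steps show that a six-membered carbon ring at this position also leaves the number within the scatter of both smaller groups. Nothing measured on these compounds accounts for this flat reading.

From the compounds shown here alone, all three groups at this position are plain carbon groups, so it remains open whether an amine or a carboxylic acid there would move the number beyond the scatter. Going by these compounds, the chloro group and the other cyclohexyl group are the same in all three compounds, so their contribution also remains open.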